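This account rests on a few compounds, and the source may have more. Where it says the series, first, only, none or still open, it means among the compounds named here.

In an ADME assay on THP-1 cells (Homo sapiens) for cytotoxicity, read by flow cytometry and propidium iodide staining, with a stated time of 72 h (on this read-out higher numbers stand for weaker inhibition and lower numbers for stronger inhibition), compound 1 `COc1ccc(-c2oc3ccc(NC(C)=O)cc3c(=O)c2O)cc1` gives 9000 nM. Compound 2 `CC(=O)Nc1ccc2oc(-c3ccc(C(F)(F)F)cc3)c(O)c(=O)c2c1` gives > 50000 nM, which is a limit of the assay and not a number, so any visible change from it can only run toward a lower number, meaning stronger inhibition. Compound 3 `Nc1ccc2oc(-c3ccc(C(F)(F)F)cc3)c(O)c(=O)c2c1` keeps the trifluoromethyl group of compound 2 but has hydrogen in place of acetyl on a nitrogen on an aromatic ring, so acetamido becomes amino (hydrogen in place of acetyl on a nitrogen on an aromatic ring). Among the compounds with values here, only one measured step is available, an at least 5.5-fold higher number from compound 1 to compound 2 (0.74 log units; beyond the scatter). It shows that a single change on this core can move the number beyond the scatter, but it was made at another place and gives no direct size for this change. A modest move toward stronger inhibition is therefore expected, though a second limit remains quite possible. The expected change is an at least 2.2-fold lower number from compound 2 to compound 3 (0.35 log units; beyond the scatter). Compound 3 is estimated at 22000 nM, with an expected range from 6000 nM to 50000 nM.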

Compound 3, half-maximal inhibitory concentration: > 125000 nM
Compound 3 gave a limit, no number (the forecaster's own chance of this, stated with the estimate: 40%); middle value at least 5.6-fold (0.75 log units) from the limit.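

The step from compound 2 to compound 3 cannot be read: each compound gives only a limit of the assay, not a number. Left open is whether the number moves at all when acetamido becomes amino on the shared core, and if so, how far and in which direction.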